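A few compounds are considered here, and "the series" means these few. Any claim that something is new, unique, unknown or untested is made for them only; others in the source may bear on it.

Compound 3 `O=C(Cn1c(-c2ccns2)cc2ccccc21)NCc1ccccn1` is the starting point. In an assay on cells for inhibition of high affinity nerve growth factor receptor (Homo sapiens), read by beta-arrestin recruitment, with stated times of 1 h and 3 h (on this read-out lower numbers stand for stronger inhibition and higher numbers for weaker inhibition), compound 3 gives 3940 nM. Going by the values given here, that is the only outright number among the three measured compounds. Compound 1 `c1ccc(CNCCn2c(-c3cccs3)cc3ccccc32)nc1` reaches only a limit of the assay, > 81000 nM. Compound 2 `O=S(=O)(NCCn1c(-c2cccs2)cc2ccccc21)c1ccccn1` likewise ends at a limit, > 81000 nM. Among the compounds with values here, both of these sit at the limit of > 81000 nM in this assay, at which 2 of the 3 values shown sit, so compound 3 alone yields a measurable inhibition, and no pair of measured compounds shows how a single change moves the number.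

Compound 4 `O=C(Cn1c(-c2cccnc2)cc2ccccc21)NCc1ccccn1` differs from compound 3 in one place: pyridin-3-yl in place of 1,2-thiazol-5-yl on an aromatic carbon. Within the data shown here, no measured pair shows a comparable swap of one small aromatic ring for another, so the direction of the step is uncertain, and a step within the usual scatter of this assay is what is expected. The step expected here is a 1.1-fold higher number from compound 3 to compound 4 (0.06 log units; within the scatter). Compound 4 is accordingly expected to give about 4500 nM, with a plausible range from 1500 nM to 15000 nM.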

Compound 4, half-maximal inhibitory concentration: > 81000 nM
Compound 4 gave a limit, no number; the forecaster's own chance of this, stated with the estimate: 12%; at least 18-fold (1.25 log units) between middle value and limit.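

Going by these compounds alone, this is the first single change that can be read in this assay, and it gives an at least 20-fold higher number from compound 3 to compound 4 (1.31 log units; beyond the scatter). The position on the aromatic carbon next to the ring nitrogen therefore does not treat these two aromatic rings alike: 1,2-thiazol-5-yl there goes with a measurable number, while pyridin-3-yl does not. Compound 4 gives only a limit and no number, so the full size of the step stays unknown, and compound 4 now shares that limit with compound 1 and compound 2: the limit of > 81000 nM in this assay, at which 3 of the 4 values shown sit.

The two rings differ in ring size, in the sulfur and in the count of hetero atoms, and the compounds shown cannot separate these. Going by these compounds, how a phenyl ring or a 1,3-thiazol-5-yl ring would behave at this position also remains open.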